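This account rests on a few compounds, and the source may have more. Where it says the series, first, only, none or still open, it means among the compounds named here.

Measured so far in an ADME assay on microsomes from liver (Homo sapiens) for metabolic stability, with a stated time of 30 min; a lower number here means that less of the compound is left, a higher number that more of the compound is left:
compound 1, `CCCCc1nc(C)c(CC(=O)OC(C)C)c(=O)n1Cc1ccc(-c2ccccc2-c2noc(=O)[nH]2)cc1`: 17.5%
compound 2, `CCCCc1nc(C)c(CC(=O)OC2CCCCC2)c(=O)n1Cc1ccc(-c2ccccc2-c2noc(=O)[nH]2)cc1`: 3.9%

Among the compounds with values here, compound 2 stands lowest of the two numbers in this assay; its only neighbour is compound 1, and the single step between them, a number 13.6 percentage points lower from compound 1 to compound 2 (beyond the scatter), is beyond the scatter and leaves compound 2 as the lower of the pair.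

Compound 3, `CCCCc1nc(C)c(CC(=O)OCC2CC2)c(=O)n1Cc1ccc(-c2ccccc2-c2noc(=O)[nH]2)cc1`, has not yet been measured in this assay. It differs from compound 2 in one place: cyclopropylmethyl in place of cyclohexyl on an oxygen next to a carbonyl group. Within the data shown here, the only measured step that bears on this change is the one on the same oxygen, a number 13.6 percentage points lower from compound 1 to compound 2 (beyond the scatter), where a bulkier ring replaced a shorter branched group and the percent remaining fell modestly. The move to cyclopropylmethyl partly reverses that direction in size, so a modest rise from compound 2 is expected, a number 7.1 percentage points higher from compound 2 to compound 3 (within the scatter), though not a full return to the level of compound 1. Compound 3 is therefore estimated at 11% in this assay, with a range of 4% to 24%.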

Compound 3, percent of the compound remaining: 20%
For compound 3 the middle estimate is 9 percentage points below the measured one, within the range that was stated.
By their numbers in this assay, from the lowest: compound 2; then compounds 1 and 3 (each within the scatter of the next).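

In this assay, cyclohexyl now stands apart from the other two groups on an oxygen next to a carbonyl group: a number 16.1 percentage points higher from compound 2 to compound 3 (beyond the scatter), so a carbon-only ring at this place does not by itself go with the low number, as cyclopropylmethyl also carries one. Cyclopropylmethyl and isopropyl cannot be told apart at this place, with a number 2.5 percentage points higher from compound 1 to compound 3 (within the scatter), although one has a three-membered ring and the other none. Nothing measured on these compounds accounts for the gap between cyclohexyl and the other two groups.

Whether the low number follows the six-membered ring or the larger count of heavy atoms stays open, since the three groups shown do not separate the two. Also open, as far as these compounds go, is what a longer straight chain, such as n-hexyl, or a chain carrying an amine would give at this oxygen.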